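Swapping the Aryl Group on a Thiourea Linker

The source may report more compounds than this note shows. Statements on the series, on what has been measured and on what is new or still open speak of the compounds shown alone.

Compound 1 `CNC(=O)c1ccc(Oc2cccc(NC(=S)Nc3cc(C(F)(F)F)cc(C(F)(F)F)c3)c2)nc1` gives 2500 nM in a functional assay on HCT-116 cells (Homo sapiens) for antiproliferative activity, read by MTT assay; a lower number here means a stronger inhibitor, a higher number a weaker inhibitor.
Compound 2 `CNC(=O)c1ccc(Oc2cccc(NC(=S)Nc3ccc(Cl)cc3Cl)c2)nc1` gives 20900 nM in this assay.

Among the measured compounds shown here, compound 2 has the highest of the two numbers; compound 1, its only neighbour, sits well below it, a gap beyond the usual scatter. Compound 3 `CNC(=O)c1ccc(Oc2cccc(NC(=S)Nc3ccc(C)cc3)c2)nc1` has not yet been measured. It differs from compound 2 in one place: 4-methylphenyl in place of 2,4-dichlorophenyl on an amide-type nitrogen. For the measured compounds named here, no measured pair isolates this change, so only a modest step is expected in this assay, more likely toward a higher number than a lower one. Compound 3 is therefore expected to give about 30000 nM, between 8000 nM and 100000 nM, an expected step of a 1.4-fold higher number from compound 2 to compound 3 (0.16 log units; within the scatter).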

Compound 3, half-maximal inhibitory concentration: 53700 nM
The estimate for compound 3 lay 1.8-fold (0.25 log units) below the measured number; the measured number falls inside the stated range.
By their numbers in this assay, from the lowest: compound 1; then compound 2; then compound 3.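

In this assay, putting 4-methylphenyl in place of 2,4-dichlorophenyl on an amide-type nitrogen gives a 2.6-fold higher number from compound 2 to compound 3 (0.41 log units; beyond the scatter), so this swap weakens the inhibitor by more than ordinary assay variation. The aryl group at this position therefore matters even when the replacement is close in size, with 7 heavy atoms entering and 8 leaving. Nothing available bears on the reason for this rise.

As far as these compounds go, whether the loss comes from losing the chlorines or from gaining the methyl remains open, as would a comparison with 4-chlorophenyl or unsubstituted phenyl. From the compounds shown here alone, how an amine or a carboxylic acid on this aryl ring would behave also remains unknown.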